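Varying the acyl group on a shared indole core

This account rests on a few compounds, and the source may have more. Where it says the series, first, only, none or still open, it means among the compounds named here.

Measured compounds:
- compound 1 `CC(=O)N(C)c1ccc2[nH]c(-c3n[nH]c4ccccc34)cc2n1`, 10300 nM
- compound 2 `CN(C(=O)C(C)(C)C)c1ccc2[nH]c(-c3n[nH]c4ccccc34)cc2n1`, 8390 nM

Among the measured compounds shown here, in a functional assay on KB cells (Homo sapiens) for antiproliferative activity, read by MTT assay, with a stated time of 72 h (on this read-out lower numbers stand for stronger inhibition and higher numbers for weaker inhibition), compound 1 gives 10300 nM, the highest of the two numbers known so far; its nearest neighbour is compound 2 with 8390 nM, and a 1.2-fold lower number from compound 1 to compound 2 (0.09 log units; within the scatter) lies within the scatter. Compound 3 `CN(C(=O)c1ccc(Br)cc1)c1ccc2[nH]c(-c3n[nH]c4ccccc34)cc2n1` has not been measured. It differs from compound 1 by 4-bromophenyl in place of methyl on a carbonyl carbon. For the measured compounds named here, the only measured step that bears on this change is the one on the same carbonyl carbon, a 1.2-fold lower number from compound 1 to compound 2 (0.09 log units; within the scatter), which shows that enlarging the group on that carbon from methyl to tert-butyl moved the number by less than the scatter. Going by the values given here, no aryl group has been tried at this position among the measured compounds, so an aromatic ring could behave differently; still, the one known step gives no reason to expect a large movement. Compound 3 is therefore expected to sit close to compound 1, with a 1.6-fold lower number from compound 1 to compound 3 (0.20 log units; within the scatter), and its estimated value is 6500 nM (range 1500 nM to 25000 nM).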

Compound 3, half-maximal inhibitory concentration: 1780 nM
Compound 3: middle estimate off by 3.7-fold (0.56 log units), on the high side; the range from low to high includes it.
By their numbers in this assay, from the lowest: compound 3; then compounds 2 and 1 (each within the scatter of the next).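

Among the compounds shown here, the change to 4-bromophenyl on the carbonyl carbon gives in this assay both a 5.8-fold lower number from compound 1 to compound 3 (0.76 log units; beyond the scatter) and a 4.7-fold lower number from compound 2 to compound 3 (0.67 log units; beyond the scatter) and so is the first change at this position to pass beyond the scatter. The position is therefore not indifferent to what the carbonyl carbon carries: methyl and tert-butyl leave the numbers within the scatter of each other, while the group with a six-membered aromatic ring and a bromine stands apart from both. Nothing measured bears on the reason for this difference. As far as these compounds go, whether the lower number goes with the aromatic ring or with the bromine stays open, and a plain phenyl or a 4-chlorophenyl on this carbon would be needed to separate the two. From the compounds shown here alone, how a pyridine ring or a longer chain ending in an amine would read at this place is also open.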